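Swapping the benzoyl phenyl for a substituted furan

The compounds below may be only part of what the source reports. "The series", "measured", "known", "first", "only" and "open" are said of these compounds alone.

Compound 1, `CCCC(=O)N1CCC(NS(=O)(=O)c2ccc(NC(=O)c3ccccc3)c3ccccc23)CC1`, gives 12.5 nM in an in vitro functional assay on CHO/Galpha16 cells for antagonist activity at C-C chemokine receptor type 8 (Homo sapiens), read by FLIPR; on this read-out lower numbers stand for stronger inhibition and higher numbers for weaker inhibition.
Compound 2, `CCCC(=O)N1CCC(NS(=O)(=O)c2ccc(NC(=O)c3ccc(C)cc3)c3ccccc23)CC1`, gives 9.5 nM.
Compound 3, `CCCC(=O)N1CCC(NS(=O)(=O)c2ccc(NC(=O)C(CC)CC)c3ccccc23)CC1`, gives 639 nM.

Among the three measured compounds, compound 1 has the second highest number: compound 2 sits within the scatter of it, while compound 3 lies far beyond it. Compound 4 is `CCCC(=O)N1CCC(NS(=O)(=O)c2ccc(NC(=O)c3cc(C)oc3C(F)(F)F)c3ccccc23)CC1`. It differs from compound 1 in one place: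

5-methyl-2-(trifluoromethyl)furan-3-yl in place of phenyl on a carbonyl carbon

Going by the values given here, two measured steps bear on this change. Adding a methyl to the aromatic ring, a 1.3-fold lower number from compound 1 to compound 2 (0.12 log units; within the scatter), changed nothing beyond the scatter. Replacing the aromatic ring by a branched chain, pentan-3-yl, a 51-fold higher number from compound 1 to compound 3 (1.71 log units; beyond the scatter), cost a great deal of potency. Among the compounds with values here, compound 4 keeps an aromatic ring on the carbonyl carbon, so the large loss seen for compound 3 is not expected to repeat, but the ring is now five-membered, carries an oxygen, and bears a trifluoromethyl as well as a methyl, and no measured compound shows what these do here. A modest weakening is therefore expected, a 2.8-fold higher number from compound 1 to compound 4 (0.45 log units; beyond the scatter), with wide uncertainty. Compound 4 is estimated at 35 nM, in a range from 8 nM to 160 nM.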

Compound 4, half-maximal inhibitory concentration: 46.9 nM
The estimate for compound 4 lay 1.3-fold (0.13 log units) below the measured number; measured number inside the range.
By their numbers in this assay, from the lowest: compounds 2 and 1 (each within the scatter of the next); then compound 4; then compound 3.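

In this assay the furan costs only a modest amount of potency, with a 3.8-fold higher number from compound 1 to compound 4 (0.57 log units; beyond the scatter) and a 4.9-fold higher number from compound 2 to compound 4 (0.69 log units; beyond the scatter) as the two steps from the benzoyl compounds. Set against the branched chain it gains far more, with a 14-fold lower number from compound 3 to compound 4 (1.13 log units; beyond the scatter) as a large step, so the five-membered aromatic ring recovers most of what pentan-3-yl lost. This position therefore accepts an aromatic ring other than a six-membered ring of carbon only, though here at a price beyond the scatter.

Ring size, the oxygen, the methyl and the trifluoromethyl all change together, so it stays open whether a plain furan ring or a phenyl carrying a trifluoromethyl would sit nearer compound 1. No measurement here explains the modest loss from phenyl to this furan.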